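The source may hold more compounds than are shown below. What is called first, only, known or untested is meant among the compounds shown, and "the series" means these compounds.

Measured compounds in an assay for inhibition of Fatty-acid amide hydrolase 1 (Rattus norvegicus); a lower number here means a stronger inhibitor, a higher number a weaker inhibitor:

Compound 1 `COC(=O)c1ccc(-c2cnc(C(=O)CCc3ccc(-c4ccccc4)cc3)o2)nc1` gives 2.2 nM.
Compound 2 `O=C(CCc1ccc(-c2ccccc2)cc1)c1ncc(-c2cccnc2)o1` gives 1.1 nM.
Compound 3 `N#Cc1cccc(-c2cnc(C(=O)CCc3ccc(COc4ccccc4)cc3)o2)n1` gives 0.56 nM.

Compound 3 has the lowest number of the three; compound 2 stands within the scatter of it, while compound 1 stands beyond it. Compound 4 `N#Cc1cccc(-c2cnc(C(=O)CCc3ccc(-c4ccccc4)cc3)o2)n1` is compound 3 with phenyl in place of phenoxymethyl on an aromatic carbon.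

Going by the values given here, the only measured step, a 2.0-fold lower number from compound 1 to compound 2 (0.30 log units; within the scatter), concerns the other end of the shared core and does not bear on this change. Compounds 1 and 2 already carry the phenyl that enters, and both stand close to compound 3 in this assay. No step beyond the scatter is therefore expected; compound 4 is estimated to sit near compound 3, with a step of a 1.8-fold higher number from compound 3 to compound 4 (0.25 log units; within the scatter), at 1 nM (range 0.35 nM to 3 nM).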

Compound 4, inhibition constant: 2.9 nM
Beside the measured number, compound 4's estimate is 2.9-fold (0.46 log units) below it, and the stated range covers the measured number.
By their numbers in this assay, from the lowest: compounds 3, 2, 1 and 4 (each within the scatter of the next, the first and the last beyond it).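

In this assay, phenyl in place of phenoxymethyl gives a 5.2-fold higher number from compound 3 to compound 4 (0.71 log units; beyond the scatter), so this place, para to a large group, responds to the change. With phenyl held fixed, 6-cyanopyridin-2-yl in place of pyridin-3-yl gives a 2.6-fold higher number from compound 2 to compound 4 (0.42 log units; beyond the scatter), while 6-cyanopyridin-2-yl in place of 5-(methoxycarbonyl)pyridin-2-yl gives a 1.3-fold higher number from compound 1 to compound 4 (0.12 log units; within the scatter). No supporting data explain these steps.

As far as these compounds go, whether the first step follows the ether oxygen or the longer link to the terminal ring remains open. A benzyl or 2-phenylethyl group at this place would separate the two.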